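This account rests on a few compounds, and the source may have more. Where it says the series, first, only, none or still open, it means among the compounds named here.

Measured so far:
compound 1, `NCCCCN(C[C@H]1Cc2cccnc2CN1)[C@H]1CCCc2cccnc21`: 6 nm/s
compound 2, `NC(=O)NC/C=C\CN(C[C@H]1Cc2ncccc2CN1)[C@H]1CCCc2cccnc21`: 2 nm/s

Among the compounds with values here, in an ADME assay for permeability, using PAMPA, with a stated time of 4 h, at pH 7.4 (a higher number here means that the compound crosses the layer faster, a lower number that the compound crosses the layer more slowly), compound 2 gives 2 nm/s, the lower of the two numbers; compound 1 gives 6 nm/s in this assay, a gap beyond the scatter, but no single-point step between the two exists, so only the two values themselves are known.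

Compound 3, `CN(CCCCN(C[C@H]1Cc2ncccc2CN1)[C@H]1CCCc2cccnc21)C1CCOCC1`, differs from compound 2 as follows: a group of 11 heavy atoms (9 carbon, 1 nitrogen, 1 oxygen; one six-membered non-aromatic ring with 1 hetero atom) in place of a group of 7 heavy atoms (4 carbon, 2 nitrogen, 1 oxygen; no ring), on a saturated chain carbon bound to an amine nitrogen

Within the data shown here, no measured pair isolates a change of this kind, so the expectation rests on the two values alone. The change is large in size and the group that enters is of a different make-up from the one that leaves, so a rise in this assay beyond the scatter is expected, with the step from a 10-fold higher number from compound 2 to compound 3 (1.00 log units; beyond the scatter) as the estimate. For compound 3 the expected permeability in this assay is 20 nm/s, within a range of 5 nm/s to 80 nm/s.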

Compound 3, apparent permeability: 490 nm/s
For compound 3 the middle estimate is 25-fold (1.39 log units) below the measured one; the whole stated range lies below it.
By their numbers in this assay, from the lowest: compound 2; then compound 1; then compound 3.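

Within this assay, the group of 11 heavy atoms with its six-membered non-aromatic ring, 0 hydrogen-bond donors and 2 hydrogen-bond acceptors, in place of the group of 7 heavy atoms with no ring, 2 hydrogen-bond donors and 1 hydrogen-bond acceptor, gives a 250-fold higher number from compound 2 to compound 3 (2.39 log units; beyond the scatter). Within the data shown here, this is the first single-place step, and it shows that the read-out can move a long way with the group carried on a saturated chain carbon bound to an amine nitrogen. Nothing measured on these compounds accounts for the size of the step.

Ring, size and hydrogen-bond counts all change together in this one step, so their shares in it stay apart from nothing yet shown. Also open, as far as these compounds go, is how a morpholine or a carboxylic acid at this place would read in this assay.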